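Aryl sulfone series: swapping the pendant aryl group

A few compounds are considered here, and "the series" means these few. Any claim that something is new, unique, unknown or untested is made for them only; others in the source may bear on it.

Two compounds of this series have a number in an ADME assay on microsomes from liver (Homo sapiens) for metabolic stability, tested at 2.5 uM; on this read-out higher numbers stand for fast clearance and lower numbers for slow clearance. Compound 1 `O=S(=O)(c1ccc(F)c(F)c1)c1cnc2c(F)cccc2c1-c1ccccc1F` gives 1.39 mL/min in this assay. Compound 2 `COc1cccc(-c2c(S(=O)(=O)c3cc(Cl)cc(Cl)c3)cnc3c(F)cccc23)c1` gives 2.31 mL/min in this assay. Compound 2 holds the higher of the two numbers, but its gap to compound 1 lies within the scatter, so the two values cannot be ordered with confidence.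

Compound 3 `O=S(=O)(c1cc(Cl)cc(Cl)c1)c1cnc2c(F)cccc2c1-c1ccccc1F` is not yet measured in this assay. It differs from compound 2 in one place: 2-fluorophenyl in place of 3-methoxyphenyl on an aromatic carbon. Going by the values given here, the group that enters is the one already present in compound 1, so compound 3 carries the sulfone aryl group of compound 2 together with the pendant aryl group of compound 1.

Among the compounds with values here, no step between measured compounds is available for this change, so the expectation rests on the two values alone. Compound 3 is expected to sit near both of them, with a step of a 1.3-fold lower number from compound 2 to compound 3 (0.11 log units; within the scatter) that stays within the scatter and, if anything, points downward because compound 1 gives 1.39 mL/min. The estimate for compound 3 in this assay is 1.8 mL/min, with a range from 1 mL/min to 3.2 mL/min.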

Compound 3, intrinsic clearance in a liver preparation (reported as CLH), per the amount of preparation that the assay uses: 0.44 mL/min
Compound 3: middle estimate off by 4.1-fold (0.61 log units), on the high side; measured number below the stated range.
By their numbers in this assay, from the lowest: compound 3; then compounds 1 and 2 (each within the scatter of the next).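

In this assay, the pendant position, on the aromatic carbon opposite the ring nitrogen, proves responsive once the sulfone aryl group is held fixed: 2-fluorophenyl in place of 3-methoxyphenyl gives a 5.3-fold lower number from compound 2 to compound 3 (0.72 log units; beyond the scatter), a step beyond the scatter that the earlier pair, differing in two places, could not show. The sulfone aryl group also moves the number with the pendant 2-fluorophenyl held fixed, as 3,5-dichlorophenyl in place of 3,4-difluorophenyl on the sulfonyl sulfur gives a 3.2-fold lower number from compound 1 to compound 3 (0.50 log units; beyond the scatter), so the combination in compound 3 holds the lowest number of the three, beyond the scatter from both neighbours. No measurement at hand accounts for either step.

The compounds shown leave open whether the pendant step keeps its size with the 3,4-difluorophenyl group on the sulfone, and whether it follows from the fluorine itself or from its place on the ring. On these data alone, how a pendant pyridyl ring, or a phenyl ring carrying an amine or a carboxylic acid, would fall on this read-out also stays open.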